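The source may report more compounds than this note shows. Statements on the series, on what has been measured and on what is new or still open speak of the compounds shown alone.

Measured in a functional assay on microsomes from liver (Rattus norvegicus) for inhibition (a higher number here means a weaker inhibitor, a lower number a stronger inhibitor), so far:
- compound 1 `COc1ccc2c(c1)CCC(Cc1ccc(O)cc1)C2=O` gives 400 nM
- compound 2 `O=C1c2ccc(O)cc2CCC1Cc1ccc(O)cc1` gives 1500 nM

Compound 2 has the higher of these two numbers, which makes it the weaker inhibitor. Compound 3 `CN(C)c1ccc(CC2CCc3cc(O)ccc3C2=O)cc1` has dimethylamino in place of hydroxy on an aromatic carbon, para to a large group (dimethylamino in place of hydroxy on an aromatic carbon). Among the compounds with values here, the only measured step, a 3.8-fold higher number from compound 1 to compound 2 (0.57 log units; beyond the scatter), is modest and changes an oxygen on an aromatic ring, not this aromatic carbon. It therefore offers only a rough guide to size, and the direction stays uncertain. In this assay the expected change is a modest one, leaning towards a lower number, estimated as a 1.7-fold lower number from compound 2 to compound 3 (0.22 log units; within the scatter). Compound 3 is expected near 900 nM, with an estimated range from 200 nM to 4000 nM.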

Compound 3, half-maximal inhibitory concentration: 1200 nM
For compound 3 the middle estimate is 1.3-fold (0.12 log units) below the measured one; the measured number falls inside the stated range.
By their numbers in this assay, from the lowest: compound 1; then compounds 3 and 2 (each within the scatter of the next).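

Replacing hydroxy with dimethylamino on this aromatic carbon gives, in this assay, a 1.3-fold lower number from compound 2 to compound 3 (0.10 log units; within the scatter) and so the two compounds cannot be told apart. At this position, then, the hydroxy with its hydrogen-bond donor can be exchanged for a larger group with no such donor without a step beyond the scatter. No measurement available here explains this result. Still open, from the compounds shown here alone, is how a plain amino group or a carboxylic acid at this place would compare. A methoxy group here would also show whether a small ether matches these two groups.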